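This account rests on a few compounds, and the source may have more. Where it says the series, first, only, none or still open, it means among the compounds named here.

Compound 1 `C=CC(=O)Nc1ccccc1CN(C(=O)Nc1cccc(C(F)(F)F)c1)C1CCN(C(C)CCC)CC1` gives 25300 nM.
Compound 2 `C#CCSc1nc(Sc2nncs2)c(C#N)c(-c2cc(OC)c(OC)c(OC)c2)n1` gives 10300 nM.
Compound 3 `C#CCSc1nc(Sc2nccs2)c(C#N)c(-c2ccc(Br)cc2)n1` gives 8530 nM.

These three numbers come from a functional assay on PC-3 cells (Homo sapiens) for antiproliferative activity, read by MTT assay, with a stated time of 72 h; a higher number here means a weaker inhibitor, a lower number a stronger inhibitor. Among them compound 3 has the lowest number. The gap to compound 2 is within the scatter, so the two cannot be told apart on these data. Compound 1 sits beyond the scatter, with the higher number of the two, so compound 3 is the stronger inhibitor of that pair. Compound 2 and compound 3 share the same core; compound 1 is built differently.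

The next compound, compound 4 `C#CCSc1nc(Sc2nccs2)c(C#N)c(-c2ccc(Cl)cc2)n1`, keeps the core of compound 3 and changes one group: chloro in place of bromo on an aromatic carbon.

For the measured compounds named here, no pair of measured compounds shows what this kind of swap does here, so there is no measured step to lean on. One halogen is exchanged for another of the same kind at the same place, and the rest of the molecule is untouched; the expectation is therefore a step of no size beyond the scatter in this assay, with no clear direction.

On that basis compound 4 is expected to give about 10000 nM, somewhere between 4000 nM and 25000 nM, which means an expected step of a 1.2-fold higher number from compound 3 to compound 4 (0.07 log units; within the scatter).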

Compound 4, half-maximal inhibitory concentration: 3620 nM
Beside the measured number, compound 4's estimate is 2.8-fold (0.44 log units) above it; measured number below the stated range.
By their numbers in this assay, from the lowest: compound 4; then compounds 3 and 2 (each within the scatter of the next); then compound 1.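

In this assay, for the compounds shown here, the exchange of bromo for chloro is the first change in this set that touches only one place, and it gives a 2.4-fold lower number from compound 3 to compound 4 (0.37 log units; beyond the scatter), a modest step but one that lies beyond the usual scatter. This shows that the position on the six-membered aromatic ring, para to a large group, is not indifferent to which halogen it carries: going from 4-bromophenyl to 4-chlorophenyl alters a single heavy atom, adds no ring and leaves the count of hydrogen-bond donors, acceptors and net charge unchanged, yet the number still moves. Nothing measured here explains why chloro gives the lower number in this pair.

A single step between two halogens cannot show a pattern, so the compounds shown leave open what a fluoro, a methoxy or an amine at the same carbon would do to the number. They also leave open whether the same exchange would give a step of similar size and direction with a different group elsewhere on the shared core.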